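Bromo for Methoxy on the Benzyl Arm: Cytotoxicity Outlook

This account rests on a few compounds, and the source may have more. Where it says the series, first, only, none or still open, it means among the compounds named here.

Compound 3 `COc1ccc(CSc2nnc(-c3cc([N+](=O)[O-])cc([N+](=O)[O-])c3)n2Cc2ccccc2)cc1` was tested in an ADME assay on HepG2 cells (Homo sapiens) for cytotoxicity, with a stated time of 48 h (a lower number here means a stronger inhibitor, a higher number a weaker inhibitor), and compound 3 gave only the limit > 30000 nM. Compound 1 `Cn1c(SCc2ccc(Br)cc2)nnc1-c1cc([N+](=O)[O-])cc([N+](=O)[O-])c1` likewise reached only the limit > 30000 nM. Compound 2 `CCCSc1nnc(-c2cc([N+](=O)[O-])cc([N+](=O)[O-])c2)n1Cc1ccccc1` also returned only the limit > 30000 nM. Every value shown therefore sits at the limit of > 30000 nM in this assay, at which 3 of the 3 values shown sit. The step that the two limits leave unreadable from compound 2 to compound 3 cannot be read from two limits. Compound 4 `O=[N+]([O-])c1cc(-c2nnc(SCc3ccc(Br)cc3)n2Cc2ccccc2)cc([N+](=O)[O-])c1` differs from compound 3 by bromo in place of methoxy on an aromatic carbon. Compound 1 carries the same 4-bromobenzyl group and shows a limit, as compound 3 does. Among the compounds with values here, no measured step offers a readable size, so no change beyond the scatter is expected in this assay, and compound 4 is expected to stay at the limit. The estimate for compound 4 is 60000 nM, ranging from 25000 nM to 200000 nM. The expected step is a step that the limit leaves unreadable from compound 3 to compound 4.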

Compound 4, half-maximal inhibitory concentration: > 30000 nM
Compound 4 gave a limit, no number; the forecaster's own chance of this, stated with the estimate: 90%; the middle value does not contradict the limit.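

Within the data shown here, no step from compound 1, compound 2 or compound 3 to compound 4 can be read, as each of these values is only a limit: the limit of > 30000 nM in this assay, at which 4 of the 4 values shown sit. The compounds shown leave open whether any of these changes alters the result in this assay.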